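A Chloro Substituent on the Core of Compound 1

The compounds below may be only part of what the source reports. "The series", "measured", "known", "first", "only" and "open" are said of these compounds alone.

Of the compounds shown here, three have so far been tested in an ADME assay on RAW264.7 cells (Mus musculus) for cytotoxicity, read by MTT assay, with a stated time of 24 h; on this read-out higher numbers stand for lower toxicity in this test and lower numbers for higher toxicity in this test. Compound 1 `O=c1oc2ccccc2c(=O)n1-c1ccc(Cl)cc1F` gives 24400 nM. Compound 2 `O=C(Nc1ccc(Cl)cc1F)c1cc(Br)ccc1O` gives 9200 nM. Compound 3 `O=c1oc2ccc(F)cc2c(=O)n1-c1ccc(Br)cc1F` gives 7200 nM. Among these three numbers compound 1 stands highest; its nearest neighbour is compound 2 and its most distant is compound 3, and both gaps lie beyond the usual scatter of this test, so compound 1 is the least toxic of the three on this read-out.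

Compound 4 `O=c1oc2ccc(Cl)cc2c(=O)n1-c1ccc(Cl)cc1F` has not yet been measured. It differs from compound 1 in a single respect: chloro in place of hydrogen on an aromatic carbon. Among the measured compounds shown here, no measured pair shows this change on its own, so any expectation rests on the numbers above. For the measured compounds named here, the only other compound with an extra substituent on the shared core is compound 3, which gives 7200 nM, the lowest number of the three. On that basis the expected step of a 1.9-fold lower number from compound 1 to compound 4 (0.27 log units; within the scatter) is a modest decrease, possibly no larger than the scatter. Compound 4 is therefore estimated at 13000 nM, with a plausible range from 4500 nM to 36000 nM.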

Compound 4, half-maximal cytotoxic concentration: 6800 nM
The estimate for compound 4 lay 1.9-fold (0.28 log units) above the measured number; the range from low to high includes it.
By their numbers in this assay, from the lowest: compounds 4, 3 and 2 (each within the scatter of the next); then compound 1.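

Among the compounds shown here, this pair gives the first direct reading of this aromatic carbon on the shared core. Compounds 1 and 4 differ only by chloro in place of hydrogen. In this assay, that single change gives a 3.6-fold lower number from compound 1 to compound 4 (0.55 log units; beyond the scatter), a step beyond the usual scatter, so this position is not indifferent to substitution: on this read-out, the chloro compound is the more toxic of the two. Nothing available explains why the added chloro has this effect.

One step cannot show whether the shift belongs to chloro itself or would follow from other groups on the same carbon, such as methoxy, an amine or a carboxylic acid. It also leaves open whether chloro would have a similar effect at other aromatic carbons of the core.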